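From fluoro to methoxy on compound 2

The source may report more compounds than this note shows. Statements on the series, on what has been measured and on what is new or still open speak of the compounds shown alone.

In a functional assay on P388 cells (Mus musculus) for inhibition (on this read-out lower numbers stand for stronger inhibition and higher numbers for weaker inhibition), compound 1 (`COc1cccc(/C=C2\Cc3ccccc3C2=O)c1`) stands at > 50000 nM as a limit of the assay, not a number. Among the measured compounds shown here, compound 2 (`O=C1/C(=C/c2ccc(F)cc2)CCCc2ccccc21`) gives 11100 nM as the only true number so far. Compound 3 (`COc1ccc(/C=C2\CCCc3ccccc3C2=O)cc1`) differs from compound 2 in one place, with methoxy in place of fluoro on an aromatic carbon, para to a large group (methoxy in place of fluoro on an aromatic carbon). For the measured compounds named here, no measured pair shows this swap. With nothing to suggest a direction, no step beyond the usual scatter is expected in this assay here. Compound 3 is expected at 10000 nM on this read-out, with an estimated range from 3000 nM to 35000 nM overall.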

Compound 3, half-maximal inhibitory concentration: 1600 nM
The estimate for compound 3 lay 6.3-fold (0.80 log units) above the measured number; measured number outside the range, below it.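

Putting methoxy in place of fluoro on an aromatic carbon, para to a large group, gives a 6.9-fold lower number from compound 2 to compound 3 (0.84 log units; beyond the scatter) in this assay. Among the compounds shown here, this is the first sign that the group at this place matters on this read-out, since compounds 1 and 2 differ in more than one place. Nothing measured here bears on why the number falls. Going by these compounds, how an amine, a hydroxyl or an ethoxy group would fare at this place stays open. A single pair also cannot tell whether the same swap would act alike on another core.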